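Thiophene in Place of Thiazole: Expected Vero Cell Toxicity

This account rests on a few compounds, and the source may have more. Where it says the series, first, only, none or still open, it means among the compounds named here.

Compound 1 `COc1cc(NCc2scnc2C)ccc1-c1cnco1`: 73700 nM
Compound 2 `COc1cc(/N=C/c2ccncc2)ccc1-c1cnco1`: 239000 nM

Of the compounds shown here, two on a shared core have been measured in an ADME assay on Vero cells (Chlorocebus sabaeus) for cytotoxicity, read by MTT assay, with a stated time of 96 h; on this read-out higher numbers stand for lower toxicity in this test and lower numbers for higher toxicity in this test. Compound 1 gives 73700 nM, the lowest of the two numbers; compound 2 gives 239000 nM, a gap that lies beyond the usual scatter of this assay. Compound 3 `COc1cc(NCc2ccsc2)ccc1-c1cnco1` has not yet been measured. It differs from compound 1 in one place: thiophen-3-yl in place of 4-methyl-1,3-thiazol-5-yl on a saturated chain carbon bound to a nitrogen on an aromatic ring. For the measured compounds named here, no measured pair shows a change of this kind, so nothing known here says how this assay answers it. Going by the values given here, since the change keeps the ring size and the carbon count and removes only one ring nitrogen and the methyl, the step of a 1.1-fold higher number from compound 1 to compound 3 (0.04 log units; within the scatter) is expected to stay within the scatter, with no clear direction. Compound 3 is therefore estimated at 80000 nM, in a range from 35000 nM to 180000 nM.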

Compound 3, half-maximal cytotoxic concentration: 181000 nM
The estimate for compound 3 lay 2.3-fold (0.35 log units) below the measured number; measured number above the stated range.
By their numbers in this assay, from the lowest: compound 1; then compounds 3 and 2 (each within the scatter of the next).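

At the position on a saturated chain carbon bound to a nitrogen on an aromatic ring, this assay does respond to the ring that is carried there: thiophen-3-yl in place of 4-methyl-1,3-thiazol-5-yl gives a 2.5-fold higher number from compound 1 to compound 3 (0.39 log units; beyond the scatter) and so points toward lower toxicity in this test. For the compounds shown here, the earlier compounds held no pair that changed this group, so this single step is the first sign that the position is not indifferent to such a swap. Nothing available bears on why the number moves.

The change removes the ring nitrogen and the methyl together, so the compounds shown leave open which of the two goes with the step. Going by these compounds, a 4-methylthiophen-3-yl or an unsubstituted 1,3-thiazol-5-yl at this position would separate them, and how a phenyl or a ring bearing an amine would read remains open as well.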